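Toward compound 3: replacing the furanylpyridine group

The compounds below may be only part of what the source reports. "The series", "measured", "known", "first", "only" and "open" are said of these compounds alone.

Measured in a functional assay on G-361 cells (Homo sapiens) for inhibition, with a stated time of 72 h (on this read-out higher numbers stand for weaker inhibition and lower numbers for stronger inhibition), so far
- compound 1 (`NC1CCC(Nc2nc(NCc3ccc(Br)cc3)c3ncn(C4CCCC4)c3n2)CC1`) gives 1480 nM
- compound 2 (`NC1CCC(Nc2nc(NCc3ccc(-c4ccco4)nc3)c3ncn(C4CCCC4)c3n2)CC1`) gives 97 nM

Compound 2 holds the lower of the two numbers at 97 nM and is clearly separated from the other compound. Compound 3 (`Nc1ccccc1CNc1nc(NC2CCC(N)CC2)nc2c1ncn2C1CCCC1`) is next, with this change from compound 2 (2-aminophenyl in place of 6-(furan-2-yl)pyridin-3-yl on a saturated chain carbon bound to a nitrogen on an aromatic ring) on the same carbon. For the measured compounds named here, the one measured step (a 15-fold lower number from compound 1 to compound 2 (1.18 log units; beyond the scatter)) is large and brought in the group that now leaves. No measurement covers 2-aminophenyl itself, but a large move in this assay to a higher number, meaning weaker inhibition, is expected. The estimated step (a 12-fold higher number from compound 2 to compound 3 (1.09 log units; beyond the scatter)) is of similar size. For compound 3 the expected value is 1200 nM with an estimated range of 350 nM to 4000 nM here.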

Compound 3, half-maximal inhibitory concentration: 2070 nM
Compound 3: the middle estimate sits 1.7-fold (0.24 log units) below what was measured; low and high end bracket the measured number.
By their numbers in this assay, from the lowest: compound 2; then compounds 1 and 3 (each within the scatter of the next).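

In this assay, 2-aminophenyl on the saturated chain carbon does not keep the lower number seen with 6-(furan-2-yl)pyridin-3-yl, with a 21-fold higher number from compound 2 to compound 3 (1.33 log units; beyond the scatter), whereas a 1.4-fold higher number from compound 1 to compound 3 (0.15 log units; within the scatter), so 2-aminophenyl and 4-bromophenyl cannot be told apart here. Among these three compounds, only the group with a five-membered aromatic ring gives a clearly separated number. Nothing available explains this difference. Still open, as far as these compounds go, is whether the furan ring or the pyridine nitrogen carries the gain in compound 2; 4-(furan-2-yl)phenyl and unsubstituted pyridin-3-yl would separate the two.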